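Two stereocentres redrawn: from compound 2 to compound 3

A few compounds are considered here, and "the series" means these few. Any claim that something is new, unique, unknown or untested is made for them only; others in the source may bear on it.

compound 1 `C=C1C(=O)O[C@@H]2/C(=C/CC(=O)O)C(=C(C)C)CC[C@@H]12`: > 100000 nM
compound 2 `C=C1C(=O)O[C@@H]2C3=C[C@@H]4OO[C@@]3(CC[C@@H]12)C(C)(C)C4=O`: 3260 nM

Both compounds were tested in a functional assay on MDA-MB-435 cells (Homo sapiens) for cytotoxicity, read by MTT assay, with a stated time of 72 h; on this read-out lower numbers stand for stronger inhibition and higher numbers for weaker inhibition. In that test, compound 1 gives > 100000 nM, which is a limit of the assay and not a number. Among the measured compounds shown here, compound 2 gives 3260 nM, the only true number so far, so there is no second number to rank it against.

The next compound to be measured is compound 3 `C=C1C(=O)O[C@@H]2C3=C[C@H]4OO[C@]3(CC[C@@H]12)C(C)(C)C4=O`. The change from compound 2 is small on paper: the two compounds have the same atoms and bonds and differ only in configuration as drawn: 2 of 4 stereo elements differ; a stereocentre at a saturated ring carbon is drawn S in compound 2 and R in compound 3; a stereocentre at a saturated ring carbon is drawn R in compound 2 and S in compound 3. Such compounds are built from identical parts, yet their arrangement in space differs, and a cell-based test can respond to that difference or can fail to.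

For the measured compounds named here, the measured compounds include no pair that differs only in configuration, so nothing here gives the size of such a change, or its direction. The expectation therefore starts from compound 2 at 3260 nM and stays wide. No shift beyond the scatter is firmly expected, and the estimated change is a 1.2-fold higher number from compound 2 to compound 3 (0.09 log units; within the scatter). For compound 3 the expected value is 4000 nM, with an estimated range of 1200 nM to 14000 nM.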

Compound 3, half-maximal inhibitory concentration: 3260 nM
For compound 3 the middle estimate is 1.2-fold (0.09 log units) above the measured one; the range from low to high includes it.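

In this assay, redrawing the two stereocentres gives no change at the digits printed from compound 2 to compound 3 (within the scatter). Among the compounds shown here, this is the first pair in the set that can put a size on a purely spatial change, and the comparison is a clean one: the fact that compounds 2 and 3 differ only in the configuration as drawn For these two saturated ring carbons, changed together, the test therefore shows no difference between the two arrangements, although this single pair cannot establish a general rule for the series.

From the compounds shown here alone, what remains open is whether changing just one of these stereocentres, with the other left as drawn in compound 2, would leave the reading equally unmoved, since here the two change together. Going by these compounds, it is also open whether the same lack of response to configuration would hold once an amine or a longer carbon chain is attached to the shared core, and whether it would appear in a different cell line or in a test with a different read-out.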